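Biaryl ether imidazolines: thiophene for methylphenyl at the ortho position

The compounds below may be only part of what the source reports. "The series", "measured", "known", "first", "only" and "open" are said of these compounds alone.

In an assay on CHO cells for displacement of a labelled ligand from Alpha-2C adrenergic receptor (Homo sapiens) (a higher number here means a weaker inhibitor, a lower number a stronger inhibitor), compound 1 `CC(Oc1ccccc1-c1cccnc1)C1=NCCN1` gives 64.6 nM, compound 2 `Cc1ccccc1-c1ccccc1OC(C)C1=NCCN1` gives 234 nM and compound 3 `Cc1cccc(-c2ccccc2OC(C)C2=NCCN2)c1` gives 245 nM. Compound 3 has the highest number of the three, but compound 2 is within the scatter of it, so the two are not distinguishable; only compound 1 stands apart, its step to compound 3 being a 3.8-fold higher number from compound 1 to compound 3 (0.58 log units; beyond the scatter).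

Compound 4 `CC(Oc1ccccc1-c1cccs1)C1=NCCN1` has not been measured in this assay. Its change from compound 3 is thiophen-2-yl in place of 3-methylphenyl on an aromatic carbon. Among the compounds with values here, two measured steps bear on it. The swap of an aryl for a heteroaryl group at the same place, seen as a 3.8-fold higher number from compound 1 to compound 3 (0.58 log units; beyond the scatter) and a 3.6-fold higher number from compound 1 to compound 2 (0.56 log units; beyond the scatter), carried a modest shift in number, while the step between the two methylphenyl isomers, a 1.0-fold higher number from compound 2 to compound 3 (0.02 log units; within the scatter), lay within the scatter. The change to compound 4 again trades a methylphenyl group for a heteroaryl one, and a modest move toward the number of compound 1 is therefore expected, with the expected step in this assay being a 2.2-fold lower number from compound 3 to compound 4 (0.35 log units; beyond the scatter).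

For compound 4 the estimated value in this assay is 110 nM, with a range from 40 nM to 320 nM.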

Compound 4, inhibition constant: 72.4 nM
The estimate for compound 4 lay 1.5-fold (0.18 log units) above the measured number; measured number inside the range.
By their numbers in this assay, from the lowest: compounds 1 and 4 (each within the scatter of the next); then compounds 2 and 3 (each within the scatter of the next).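

In this assay, thiophen-2-yl on this aromatic carbon, ortho to a group of 8 heavy atoms, gives a 3.4-fold lower number from compound 3 to compound 4 (0.53 log units; beyond the scatter) when it replaces 3-methylphenyl and a 3.2-fold lower number from compound 2 to compound 4 (0.51 log units; beyond the scatter) when it replaces 2-methylphenyl, so the lower number seen earlier with pyridin-3-yl is not confined to that one heteroaryl group. Thiophen-2-yl and pyridin-3-yl cannot be told apart here, with a 1.1-fold higher number from compound 1 to compound 4 (0.05 log units; within the scatter), so the change from a six-membered to a five-membered aromatic ring, and from nitrogen to sulfur as the hetero atom, leaves the number within the scatter, and among these four compounds both heteroaryl groups give lower numbers than both methylphenyl groups, with no compound going against that split. No measured data on these compounds speak to what lies behind this split.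

The methylphenyl groups differ from the heteroaryl groups both in the ring and in the methyl substituent, so an unsubstituted phenyl at this place would be needed to separate the two. Going by these compounds, whether the split extends to other heteroaryl groups, such as furan-2-yl or thiophen-3-yl, remains open.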